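Furan for Pyrrole in a Cyanoacrylamide Growth Inhibitor

A few compounds are considered here, and "the series" means these few. Any claim that something is new, unique, unknown or untested is made for them only; others in the source may bear on it.

Compound 1 `N#C/C(=C\c1ccc(Cl)cc1)C(=O)c1ccc[nH]1`, 61000 nM
Compound 2 `COc1ccc(CNC(=O)/C(C#N)=C/c2ccc[nH]2)cc1`, > 50000 nM

In a functional assay on DU-145 cells (Homo sapiens) for inhibition, read by MTT assay, with a stated time of 72 h (a higher number here means a weaker inhibitor of growth, a lower number a stronger inhibitor of growth), compound 1 gives 61000 nM. For compound 2 this assay reports no number but only a limit, > 50000 nM, so compound 2 sits at the limit of > 50000 nM in this assay, at which 1 of the 2 values shown sits. Compound 3 `COc1ccc(CNC(=O)/C(C#N)=C/c2ccco2)cc1` differs from compound 2 by furan-2-yl in place of 1H-pyrrol-2-yl on a double-bonded chain carbon bound to a double-bonded chain carbon. For the measured compounds named here, no measured step covers this change; the expected step that the limit leaves unreadable from compound 2 to compound 3 is none beyond the usual scatter. Compound 3 is therefore estimated at 60000 nM, within a range from 20000 nM to 200000 nM, most likely again reported as a limit.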

Compound 3, concentration for 50% growth inhibition: 29000 nM
For compound 3 the middle estimate is 2.1-fold (0.32 log units) above the measured one; the measured number falls inside the stated range.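

In this assay, furan-2-yl in place of 1H-pyrrol-2-yl on this carbon gives an at least 1.7-fold lower number from compound 2 to compound 3 (0.23 log units; that floor lies within the scatter). The change removes the hydrogen-bond donor counted on 1H-pyrrol-2-yl, and the number does not rise, so this donor is not needed for the growth inhibition that compound 3 shows. How large the step really is cannot be read, as compound 2 is held only at a limit: the limit of > 50000 nM in this assay, at which 1 of the 3 values shown sits.

The compounds shown leave open whether thiophen-2-yl, with sulfur as its ring atom, would serve here as well. They also leave open what an amine or a carboxylic acid on that phenyl-free carbon would do.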